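This account rests on a few compounds, and the source may have more. Where it says the series, first, only, none or still open, it means among the compounds named here.

Measured so far:
- Compound 1 `N#Cc1ccc(OCc2cn(C(c3ccc(C#N)cc3)c3ccc(C#N)cc3)nn2)cc1`: in an assay on isolated protein for inhibition of Aromatase (Homo sapiens), read by fluorescence and colorimetric assay, with a stated time of 30 min (on this read-out lower numbers stand for stronger inhibition and higher numbers for weaker inhibition), compound 1 gives 4640 nM
- Compound 2 `N#Cc1ccc(Cn2cc(COc3ccccc3)nn2)cc1`: in this assay compound 2 gives 6090 nM
- Compound 3 `N#Cc1ccc(Cn2cc(COc3ccc(Cl)cc3)nn2)cc1`: in this assay compound 3 gives 3910 nM

Compound 3 stands at the low end of these three numbers, but its distance to compound 1 and its distance to compound 2 both fall within the usual scatter, so the three compounds cannot be told apart on this read-out.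

The next compound is compound 4 `N#Cc1ccc(Cn2cc(COc3ccc(C#N)cc3)nn2)cc1`. Against compound 3 the change is cyano in place of chloro on an aromatic carbon.

Among the compounds with values here, only one measured step touches the same place: a 1.6-fold lower number from compound 2 to compound 3 (0.19 log units; within the scatter). It shows that putting a group at this position changed little. Within the data shown here, compound 1 carries a cyano group at the same place, though it differs from compound 3 elsewhere as well, so no single step can be drawn; its value and that of compound 3 simply sit close together.

On this basis no movement beyond the scatter is expected in this assay. The step of a 1.1-fold higher number from compound 3 to compound 4 (0.03 log units; within the scatter) is estimated to be small. Compound 4 is expected to give about 4200 nM, within a range from 2000 nM to 9000 nM.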

Compound 4, half-maximal inhibitory concentration: 9160 nM
The estimate for compound 4 lay 2.2-fold (0.34 log units) below the measured number; measured number outside the range, above it.
By their numbers in this assay, from the lowest: compounds 3, 1, 2 and 4 (each within the scatter of the next, the first and the last beyond it).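

In this assay, within the data shown here, cyano in place of chloro gives a 2.3-fold higher number from compound 3 to compound 4 (0.37 log units; beyond the scatter), the first step at this position to pass the scatter, so the two groups can be told apart here, though only modestly. Neither group separates from hydrogen: cyano in place of hydrogen gives a 1.5-fold higher number from compound 2 to compound 4 (0.18 log units; within the scatter) and chloro in place of hydrogen gave a 1.6-fold lower number from compound 2 to compound 3 (0.19 log units; within the scatter), so the difference appears only when the two groups are set directly against each other. Hydrogen in place of 4-cyanophenyl on the saturated chain carbon gives a 2.0-fold higher number from compound 1 to compound 4 (0.30 log units; within the scatter), so with cyano at this position, that change elsewhere in the molecule does not separate the two compounds.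

Nothing at hand accounts for the gap between chloro and cyano. On these data alone, it remains open how an amine, a carboxylic acid or a methoxy group at this position would compare, and whether any group here could move the number well beyond the modest step seen so far.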